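The source may report more compounds than this note shows. Statements on the series, on what has been measured and on what is new or still open speak of the compounds shown alone.

In an in vivo ADME assay on the whole organism (strain 129/SvEvBrd x C57BL/6) for pharmacokinetics, with Mus musculus as the target, at a dose of 1 mg/kg by the intravenous route (a higher number here means faster removal of the compound, a lower number slower removal), compound 1 `CC(O)c1nc([C@@H](O)[C@H](O)[C@H](O)CO)c[nH]1` gives 16.4 mL/min/kg. Compound 2 `OC[C@@H](O)[C@@H](O)[C@H](O)c1c[nH]c(-c2ncn(Cc3ccccc3)n2)n1` gives 16.4 mL/min/kg, so compound 1 stands level with it. Compound 3 `OC[C@@H](O)[C@@H](O)[C@H](O)c1c[nH]c(-c2ncon2)n1` has yet to be measured. It carries 1,2,4-oxadiazol-3-yl in place of 1-hydroxyethyl on an aromatic carbon. Among the measured compounds shown here, no step between measured compounds shows what such a change does, so no shift beyond the scatter is assumed. The expected step is a 1.2-fold higher number from compound 1 to compound 3 (0.09 log units; within the scatter), an estimate that stays within the scatter of this assay. For compound 3 the expected clearance is 20 mL/min/kg, with an estimated range of 8 mL/min/kg to 45 mL/min/kg.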

Compound 3, clearance: 11.3 mL/min/kg
Compound 3: the middle estimate sits 1.8-fold (0.25 log units) above what was measured; measured number inside the range.
By their numbers in this assay, from the lowest: compounds 3, 1 and 2 (each within the scatter of the next).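

In this assay, 1,2,4-oxadiazol-3-yl in place of 1-hydroxyethyl on an aromatic carbon gives a 1.5-fold lower number from compound 1 to compound 3 (0.16 log units; within the scatter) as the first step read at this position. Clearance thus stays within the scatter when a five-membered aromatic ring with 3 hetero atoms replaces an open group carrying a hydrogen-bond donor. Nothing measured alongside this result accounts for it. The compounds shown leave open whether an amine or a carboxylic acid on this aromatic carbon would move clearance beyond the scatter.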